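A few compounds are considered here, and "the series" means these few. Any claim that something is new, unique, unknown or untested is made for them only; others in the source may bear on it.

Compounds measured in a functional assay on ileum (Cavia porcellus) for antagonist activity at cysteinyl leukotriene receptor (Homo sapiens); on this read-out higher numbers stand for weaker inhibition and lower numbers for stronger inhibition:
- compound 3, `CCC(CC)(CC(=O)Nc1cccc(OCc2ccc3ccccc3n2)c1)C(=O)O`, gives 0.9 nM
- compound 1, `CCC(CC)(CC(=O)Nc1cccc(OCc2ccc3cc(F)ccc3n2)c1)C(=O)O`, gives 2 nM
- compound 2, `CCC(CC)(CC(=O)Nc1cccc(OCc2ccc3cccc(F)c3n2)c1)C(=O)O`, gives 6 nM

Compound 3 carries the lowest number of the three in this assay; compound 1 lies nearest, and the step of a 2.2-fold lower number from compound 1 to compound 3 (0.35 log units; beyond the scatter) is beyond the scatter, while compound 2 is furthest, with the step of a 6.7-fold lower number from compound 2 to compound 3 (0.82 log units; beyond the scatter) also beyond the scatter. Both measured steps describe a hydrogen in place of fluoro on an aromatic carbon of the shared core, and in each case the unsubstituted compound 3 gave the lower number.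

Compound 4, `CCC(CC)(CC(=O)Nc1cccc(OCc2ccc3ccc(C)cc3n2)c1)C(=O)O`, differs from compound 3 by methyl in place of hydrogen on an aromatic carbon. Going by the values given here, no measured step shows a methyl on this ring, so the two fluoro steps are the only guide, and they point the same way: a substituent on this ring of the core has so far raised the number in this assay, by a modest amount in one case and more in the other. A methyl at a further position is therefore expected to move compound 4 in the same direction, with a step of about a 2.4-fold higher number from compound 3 to compound 4 (0.39 log units; beyond the scatter). The estimate for compound 4 in this assay is 2.2 nM, with a range from 0.7 nM to 7 nM.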

Compound 4, half-maximal inhibitory concentration: 11 nM
Compound 4: the middle estimate sits 5.0-fold (0.70 log units) below what was measured; the whole stated range lies below it.
By their numbers in this assay, from the lowest: compound 3; then compound 1; then compounds 2 and 4 (each within the scatter of the next).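

In this assay, a single methyl on an aromatic carbon of the six-membered aromatic ring of carbon only, meta to a fused ring and para to a fused ring, brings a 12-fold higher number from compound 3 to compound 4 (1.09 log units; beyond the scatter), a large step, whereas the two fluoro steps, a 2.2-fold lower number from compound 1 to compound 3 (0.35 log units; beyond the scatter) and a 6.7-fold lower number from compound 2 to compound 3 (0.82 log units; beyond the scatter), were modest. This shows that a change of only one heavy atom on this ring can cost far more than either fluoro did, so the earlier modest steps do not set the size of what a substituent on this ring can do. All three substituted compounds now carry higher numbers than unsubstituted compound 3, with none going against that among the compounds shown, but no measurement offered here explains why the methyl step is so large.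

Fluoro and methyl appear only on different carbons in these compounds, so they leave open whether the large step belongs to the methyl group, to this carbon, or to the two together. On these data alone, how a chloro, a methoxy or an amine on this same carbon would read in this assay also remains open.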